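Amide variations on a benzothiazolyl thioether scaffold

This account rests on a few compounds, and the source may have more. Where it says the series, first, only, none or still open, it means among the compounds named here.

Compound 1, `COc1ccccc1C(=O)Nc1ccc(Sc2nc3ccccc3s2)cc1`, in an assay on isolated protein for inhibition of thiosulfate sulfurtransferase (Homo sapiens), with a stated time of 60 min, in the absence of a further agent; on this read-out higher numbers stand for weaker inhibition and lower numbers for stronger inhibition: > 100000 nM, a limit of the assay.
Compound 2, `O=C(Nc1ccc(Sc2nc3ccccc3s2)cc1)c1ccccc1`: > 100000 nM, a limit of the assay.
Compound 3, `O=C(Nc1ccc(Sc2nc3ccccc3s2)cc1)c1ccccc1O`: > 100000 nM, a limit of the assay.

Compound 3 stands only at a limit in this assay, and the two further values shown are limits as well, so no ordering among the three measured compounds can be read. The steps between them are accordingly unreadable: a step that the two limits leave unreadable from compound 1 to compound 2, a step that the two limits leave unreadable from compound 1 to compound 3 and a step that the two limits leave unreadable from compound 2 to compound 3. Nothing beyond the fact that the limit of > 100000 nM in this assay, at which 3 of the 3 values shown sit, can be drawn from them.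

Compound 4, `O=C(Nc1ccc(Sc2nc3ccccc3s2)cc1)c1cccc(Br)c1`, differs from compound 3 in that (3-bromophenyl in place of 2-hydroxyphenyl on a carbonyl carbon). Among the measured compounds shown here, none of the measured steps touches a bromine or a 3-substituted ring, so none bears directly on this change. The three measured compounds offer only the shared observation of a limit, and the expectation for compound 4 therefore rests on that alone. Compound 4 is expected to give 100000 nM in this assay, within 30000 nM to 300000 nM. The estimated step from compound 3 to compound 4 is a number no higher from compound 3 to compound 4 (the limit leaves the size open), with the most likely outcome being another limit rather than a number.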

Compound 4, half-maximal inhibitory concentration: > 100000 nM
Compound 4: only a limit was reported; the forecaster's own chance of this, stated with the estimate: 75%; the middle value sits exactly at the limit.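

In this assay compound 4 gives > 100000 nM, a limit of the assay. Its steps from compound 1, compound 2 and compound 3 cannot be read. All four compounds share one result: the limit of > 100000 nM in this assay, at which 4 of the 4 values shown sit. The compounds shown leave open whether any change to the group on the carbonyl carbon would bring a value that can be read as a number.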